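The source may hold more compounds than are shown below. What is called first, only, known or untested is meant among the compounds shown, and "the series" means these compounds.

Measured so far in a toxicity assay on MDCK cells (Canis lupus familiaris) for cytotoxicity, read by crystal violet staining, with a stated time of 48 h; on this read-out higher numbers stand for lower toxicity in this test and lower numbers for higher toxicity in this test:
- compound 1 `Cc1ccc2[nH]c(=O)c(CN(Cc3ccc(F)cc3)Cc3ccc(C(C)(C)C)cc3)cc2c1`: > 27000 nM, a limit of the assay.
- compound 2 `COCOc1ccc(CN(Cc2ccc(C(C)(C)C)cc2)Cc2cc3cc(C)ccc3[nH]c2=O)cc1`: 6400 nM.
- compound 3 `Cc1ccc2[nH]c(=O)c(CN(Cc3ccc(SC(F)(F)F)cc3)Cc3ccc(C(C)(C)C)cc3)cc2c1`: > 5000 nM, a limit of the assay.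

Compound 3 stands only at a limit in this assay, and its place against the other two cannot be read. The step that the two limits leave unreadable from compound 1 to compound 3 and the step that the limit leaves unreadable from compound 2 to compound 3 are both unreadable because the limit of > 5000 nM in this assay, at which 1 of the 3 values shown sits, is all that is shown for compound 3. Within the data shown here, the one readable step is an at least 4.2-fold lower number from compound 1 to compound 2 (0.62 log units; beyond the scatter), which runs toward higher toxicity.

Compound 4 `Cc1ccc2[nH]c(=O)c(CN(Cc3ccc(C(C)(C)C)cc3)Cc3ccc(N(C)C)c(Cl)c3)cc2c1` differs from compound 3 by 3-chloro-4-(dimethylamino)phenyl in place of 4-((trifluoromethyl)sulfanyl)phenyl on a saturated chain carbon bound to an amine nitrogen. Every measured step changes the substituent on the same benzyl group, and none brings in 3-chloro-4-(dimethylamino)phenyl; they bear on the new step only loosely, showing that the series has stayed at low toxicity in this assay across three different groups at that place. With compound 3 at a limit, no direction beyond the scatter is readable, and the step that the limit leaves unreadable from compound 3 to compound 4 is expected to be small. Compound 4 is expected at 10000 nM, within 3000 nM to 40000 nM.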

Compound 4, half-maximal cytotoxic concentration: > 10000 nM
Compound 4 was reported as a limit; the forecaster's own chance of this, stated with the estimate: 50%; the middle value sits exactly at the limit.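

In this assay compound 4 gives > 10000 nM, which is a limit of the assay. Among these compounds, at this place, on a saturated chain carbon bound to an amine nitrogen, 3-chloro-4-(dimethylamino)phenyl is the first group with a nitrogen and a chlorine, and the only readable comparison is an at least 1.5-fold higher number from compound 2 to compound 4 (0.19 log units; that floor lies within the scatter), so no separation from compound 2 is established. The steps to compound 4 from compound 1 and from compound 3 cannot be read, because compound 4 stands only at a limit: the limit of > 10000 nM in this assay, at which 1 of the 4 values shown sits.

As far as these compounds go, the true order of compound 1, compound 3 and compound 4 remains open, as only compound 2 has a measured number. Also open, from the compounds shown here alone, is how 4-(dimethylamino)phenyl without the chlorine, or a phenyl carrying a carboxylic acid, would read at this place in this assay.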